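Para substituent exchange on a benzoate ester series

The source may hold more compounds than are shown below. What is called first, only, known or untested is meant among the compounds shown, and "the series" means these compounds.

The measured compounds and their values:

Compound 1 `Cc1ccc(C(=O)OC2(C(=O)Nc3ccc([N+](=O)[O-])cc3)CCCCC2)cc1` gives 45.4 nM in a functional assay on NFS-60 cells (Mus musculus) for inhibition, read by MTT assay, with a stated time of 72 h; on this read-out lower numbers stand for stronger inhibition and higher numbers for weaker inhibition.
Compound 2 `O=C(OC1(C(=O)Nc2ccc([N+](=O)[O-])cc2)CCCCC1)c1ccc(Cl)cc1` gives 10.3 nM in this assay.
Compound 3 `COc1ccc(C(=O)OC2(C(=O)Nc3ccc([N+](=O)[O-])cc3)CCCCC2)cc1` gives 38.8 nM in this assay.

Compound 3 stands second highest of the three numbers. Its nearest neighbour is compound 1, with a 1.2-fold lower number from compound 1 to compound 3 (0.07 log units; within the scatter) separating them, a gap within the scatter. Its furthest neighbour is compound 2, reached by a 3.8-fold higher number from compound 2 to compound 3 (0.58 log units; beyond the scatter), a gap that goes beyond the scatter.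

Compound 4 `O=C(OC1(C(=O)Nc2ccc([N+](=O)[O-])cc2)CCCCC1)c1ccc(Br)cc1` is not yet measured. It differs from compound 3 by bromo in place of methoxy on an aromatic carbon.

Going by the values given here, two measured steps bear on this change. The exchange of chloro for methoxy at the same place, a 3.8-fold higher number from compound 2 to compound 3 (0.58 log units; beyond the scatter), raised the number by a modest amount, and the exchange of methyl for chloro, a 4.4-fold lower number from compound 1 to compound 2 (0.64 log units; beyond the scatter), lowered it. Among the compounds with values here, no bromo compound has been measured, so the size of the bromo step is taken from the chloro step as the closest available comparison. Compound 4 is therefore expected to show a modestly lower number than compound 3 in this assay, a step of about a 3.0-fold lower number from compound 3 to compound 4 (0.47 log units; beyond the scatter). The estimate for compound 4 is 13 nM, with a range from 5 nM to 35 nM.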

Compound 4, half-maximal inhibitory concentration: 236 nM
Estimate against measurement, compound 4: 18-fold (1.26 log units) below; the measured number lies above the stated range.
By their numbers in this assay, from the lowest: compound 2; then compounds 3 and 1 (each within the scatter of the next); then compound 4.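

Swapping chloro for bromo at this aromatic carbon gives a 23-fold higher number from compound 2 to compound 4 (1.36 log units; beyond the scatter) in this assay, so in this series the chloro result does not carry over to bromo, even though the two groups are both halogens. Bromo also separates from the other two groups, with a 5.2-fold higher number from compound 1 to compound 4 (0.72 log units; beyond the scatter) and a 6.1-fold higher number from compound 3 to compound 4 (0.78 log units; beyond the scatter), which leaves compound 4 with the highest number of the four and every step to it beyond the scatter. The earlier compounds shown here showed only that chloro gave a lower number than methyl or methoxy, whereas compounds 2 and 4 now sit at opposite ends of the series, so carrying a halogen at this place does not by itself give a low number here.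

The compounds shown leave open where fluoro, iodo, an amine or a carboxylic acid at this place would fall, and whether the wide gap between chloro and bromo would persist on a core other than the one shared here. No evidence is available that accounts for this gap between the two halogens.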